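A few compounds are considered here, and "the series" means these few. Any claim that something is new, unique, unknown or untested is made for them only; others in the source may bear on it.

Compound 1 `CC1=C(/C=C/C(=O)/C=C/c2ccccc2)C(C)(C)CCC1O` carries an unsubstituted aromatic ring, and in a functional assay on LNCaP cells (Homo sapiens) for cytotoxicity, read by MTT assay, with a stated time of 72 h (a lower number here means a stronger inhibitor, a higher number a weaker inhibitor), compound 1 gives 5800 nM. Compound 2 `CC1=C(/C=C/C(=O)/C=C/c2cccc(C(F)(F)F)c2)C(C)(C)CCC1O` differs from it by trifluoromethyl in place of hydrogen on an aromatic carbon; in this assay compound 2 gives 740 nM, which is a 7.8-fold lower number from compound 1 to compound 2 (0.89 log units; beyond the scatter). Compound 3 `CC1=C(/C=C/C(=O)/C=C/c2ccccc2F)C(C)(C)CCC1O` differs from compound 1 by fluoro in place of hydrogen on an aromatic carbon; in this assay compound 3 gives 2900 nM, and the step is a 2.0-fold lower number from compound 1 to compound 3 (0.30 log units; within the scatter), so compounds 1 and 3 cannot be told apart here.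

Compound 4 `CC1=C(/C=C/C(=O)/C=C/c2c(F)cccc2C(F)(F)F)C(C)(C)CCC1O` has not yet been measured. It differs from compound 3 by trifluoromethyl in place of hydrogen on an aromatic carbon. This is the same kind of change as that from compound 1 to compound 2, not the same one: in compound 4 the trifluoromethyl sits ortho to a large group and meta to a fluoro group, whereas in compound 2 it sits meta to a large group. Because a 7.8-fold lower number from compound 1 to compound 2 (0.89 log units; beyond the scatter) was seen for this kind of change, compound 4 is expected to show a step of a 4.8-fold lower number from compound 3 to compound 4 (0.68 log units; beyond the scatter) in this assay, tempered by the different place. In this assay compound 4 is therefore estimated at 600 nM, expected to lie between 200 nM and 2000 nM.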

Compound 4, half-maximal inhibitory concentration: 4900 nM
Compound 4: the middle estimate sits 8.2-fold (0.91 log units) below what was measured; the whole stated range lies below it.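

In this assay, trifluoromethyl in place of hydrogen on an aromatic carbon gives a 1.7-fold higher number from compound 3 to compound 4 (0.23 log units; within the scatter), so compounds 3 and 4 cannot be told apart here. Set beside the earlier step, the change does not carry over from the core of compound 1 to the fluoro-bearing core of compound 3: the same change on two cores in this assay, a 7.8-fold lower number (0.89 log units; beyond the scatter) from compound 1 to compound 2 and a 1.7-fold higher number (0.23 log units; within the scatter) from compound 3 to compound 4, 13-fold (1.12 log units) apart, beyond the scatter of two such steps. This shows that the step seen for compound 2 cannot be taken to another member of the series as a fixed amount, but it does not show why: the two steps differ both in the core and in the place of the trifluoromethyl, which in compound 4 sits ortho to a large group and meta to a fluoro group, and the compounds shown do not separate the two.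

The compounds shown leave open whether trifluoromethyl at another place on the fluoro-bearing ring would give a step like the earlier one. They also leave open whether a different group at that place, such as a nitrile, a methoxy group or an amine, would follow compound 2 or compound 4.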